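Phenyl to cyclohexyl across two cores

This account rests on a few compounds, and the source may have more. Where it says the series, first, only, none or still open, it means among the compounds named here.

Compound 1 `O=C(COc1ccc(-c2ccccc2)cc1)Nc1cccc(-c2nc3ncccc3o2)c1` gives 630 nM in an assay on brain for inhibition of Fatty-acid amide hydrolase 1 (Rattus norvegicus); a lower number here means a stronger inhibitor, a higher number a weaker inhibitor. Compound 2 `O=C(COc1ccc(C2CCCCC2)cc1)Nc1cccc(-c2nc3ncccc3o2)c1` gives 2600 nM in this assay; the change cyclohexyl in place of phenyl on an aromatic carbon gives a 4.1-fold higher number from compound 1 to compound 2 (0.62 log units; beyond the scatter). Compound 3 `O=C(COc1ccc(-c2ccccc2)cc1)Nc1ccccc1-c1nc2ncccc2[nH]1` gives 1100 nM in this assay; its value and that of compound 1 lie within the scatter of each other, while compound 2 shows the higher number of the three. How the core of compound 3 differs from that of compound 1 is not broken down here.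

Compound 4 `O=C(COc1ccc(C2CCCCC2)cc1)Nc1ccccc1-c1nc2ncccc2[nH]1` is not yet measured. It carries the change (cyclohexyl in place of phenyl on an aromatic carbon), the same change as between compound 1 and compound 2. Within the data shown here, for compound 4 a step of a 3.6-fold higher number from compound 3 to compound 4 (0.56 log units; beyond the scatter) is expected, resting on compound 1 and compound 2 because a 4.1-fold higher number from compound 1 to compound 2 (0.62 log units; beyond the scatter) is the only measured instance of this change. Compound 4 is estimated at 4000 nM, with a likely range from 1500 nM to 12000 nM.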

Compound 4, half-maximal inhibitory concentration: 650 nM
Beside the measured number, compound 4's estimate is 6.2-fold (0.79 log units) above it; the measured number lies below the stated range.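

On the core of compound 3, cyclohexyl in place of phenyl gives a 1.7-fold lower number from compound 3 to compound 4 (0.23 log units; within the scatter), so the loss seen on the core of compound 1 does not reappear. The two steps disagree in this assay: the same change on two cores in this assay, a 4.1-fold higher number (0.62 log units; beyond the scatter) from compound 1 to compound 2 and a 1.7-fold lower number (0.23 log units; within the scatter) from compound 3 to compound 4, 7.0-fold (0.84 log units) apart, beyond the scatter of two such steps

For these two pairs, the effect of the change depends on the core; the pairs do not show which difference between the cores matters, and one pair per core gives no rule for other cores.

Still open, on these data alone, is how a piperidine or a straight hexyl chain in the same place would behave on each core. Also open, as far as these compounds go, is whether either would follow compound 2 or compound 4.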